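The compounds below may be only part of what the source reports. "The series", "measured", "known", "first", "only" and "open" are said of these compounds alone.

Measured so far in an assay on Ltk cells with metabotropic glutamate receptor 5 (Homo sapiens) as the target, read by fluorescence and calcium flux; a higher number here means a weaker inhibitor, a lower number a stronger inhibitor:

Compound 1, `Cc1cccc(NC(=O)c2nc(C)ccc2O)n1`, gives 7 nM.
Compound 2, `CCOc1cccnc1Nc1cccc(C)n1`, gives 40 nM.
Compound 3, `CCOc1cc(-c2ccc(C)cc2)cnc1Nc1cccc(C)n1`, gives 513 nM.

Compound 3 gives the highest of these three numbers, so in this assay it is the weakest inhibitor of the set: its nearest neighbour is compound 2 and the furthest is compound 1, and both gaps lie beyond the usual scatter. Among the measured compounds shown here, the one measured step that touches the same spot on the shared core is a 13-fold higher number from compound 2 to compound 3 (1.11 log units; beyond the scatter), in which a 4-methylphenyl group entered in place of hydrogen on an aromatic carbon and the number rose sharply.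

Compound 4, `CCOc1cc(-c2cnccc2C)cnc1Nc1cccc(C)n1`, differs from compound 3 by 4-methylpyridin-3-yl in place of 4-methylphenyl on an aromatic carbon. For the measured compounds named here, no measured pair shows what happens when one aromatic ring at this spot gives way to another that carries a ring nitrogen, so the step from compound 2 to compound 3 tells only that a ring here is poorly tolerated, not how the two rings compare with each other. Because a 13-fold higher number from compound 2 to compound 3 (1.11 log units; beyond the scatter) was large while the present swap keeps the ring and its methyl group, the expected change is small: the step from compound 3 to compound 4 is estimated at a 1.3-fold lower number from compound 3 to compound 4 (0.11 log units; within the scatter), within the scatter. Compound 4 is therefore expected to give about 400 nM, in a range from 100 nM to 1600 nM.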

Compound 4, half-maximal inhibitory concentration: 45 nM
For compound 4 the middle estimate is 8.9-fold (0.95 log units) above the measured one, and the stated range ends above it.
By their numbers in this assay, from the lowest: compound 1; then compounds 2 and 4 (each within the scatter of the next); then compound 3.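

In this assay, a ring at this position is not penalised in itself: an 11-fold lower number from compound 3 to compound 4 (1.06 log units; beyond the scatter) comes with nothing more than 4-methylpyridin-3-yl in place of 4-methylphenyl, two groups of the same heavy-atom count, one of which carries a ring nitrogen. Set against the hydrogen of compound 2, a 1.1-fold higher number from compound 2 to compound 4 (0.05 log units; within the scatter) shows that the 4-methylpyridin-3-yl group sits on this aromatic carbon with no difference beyond the scatter, so the earlier 13-fold higher number from compound 2 to compound 3 (1.11 log units; beyond the scatter) belongs to the 4-methylphenyl group and not to every ring placed here. Nothing available explains why the two rings part so sharply.

The two group names also differ in where the methyl sits on the ring, so the ring nitrogen and the methyl placement cannot be told apart from these compounds alone. A 2-methylphenyl group would separate those two changes, and a pyridin-3-yl group without its methyl would show whether the methyl matters at all.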